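Phenoxy for methyl on the benzamide of compound 2

The source may report more compounds than this note shows. Statements on the series, on what has been measured and on what is new or still open speak of the compounds shown alone.

Measured compounds:
compound 1, `Cc1cccc(NC(=O)c2cccc3ccccc23)n1`, 62800 nM
compound 2, `Cc1cccc(C(=O)Nc2cccc(C)n2)c1`, 1840 nM

Of the compounds shown here, two have been measured in an assay on membranes from brain for binding affinity to metabotropic glutamate receptor 5 (Rattus norvegicus); a higher number here means a weaker inhibitor, a lower number a stronger inhibitor. Compound 1 gives 62800 nM, while compound 2 gives 1840 nM. Compound 2 thus stands at the lower of the two numbers, and compound 1 sits well above it, a gap that lies beyond the usual scatter of this assay.

Compound 3, `Cc1cccc(NC(=O)c2cccc(Oc3ccccc3)c2)n1`, has not yet been measured. Its difference from compound 2 is phenoxy in place of methyl on an aromatic carbon. The shared core of compound 2 and compound 3 is the same; only the group on one aromatic carbon of the acyl-side ring is exchanged.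

Within the data shown here, no step between measured compounds touches this position directly. Among the measured compounds shown here, the only comparison at hand is compound 1, whose larger aromatic acyl side goes with a much higher number than compound 2. On that basis the step is expected to go upward, toward a weaker inhibitor, by an amount estimated as a 3.3-fold higher number from compound 2 to compound 3 (0.51 log units; beyond the scatter). Compound 3 is therefore estimated at 6000 nM, within a range from 1200 nM to 30000 nM.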

Compound 3, half-maximal inhibitory concentration: 57000 nM
For compound 3 the middle estimate is 9.5-fold (0.98 log units) below the measured one; the measured number lies above the stated range.
By their numbers in this assay, from the lowest: compound 2; then compounds 3 and 1 (each within the scatter of the next).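

In this assay, among these compounds, the exchange of methyl for phenoxy on an aromatic carbon, meta to a large group, gives the first direct reading of this position: a 31-fold higher number from compound 2 to compound 3 (1.49 log units; beyond the scatter). The position therefore does not take this change without a large rise in the number, which the comparison of the two earlier compounds could not show, since they do not differ at this carbon alone. The entering phenoxy brings more heavy atoms, a further six-membered aromatic ring and a hydrogen-bond acceptor, but this single step cannot separate these features, and nothing measured here accounts for its size.

The compounds shown leave open whether the number climbs gradually with the size of the group or rises only once a second ring is present, which an ethyl or methoxy group on the same carbon would help to settle. They also leave open what the oxygen contributes, a question that a phenyl group on that carbon, without the oxygen, would address.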